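Swapping a hydroxyalkyl chain for phenyl on the amine

The source may hold more compounds than are shown below. What is called first, only, known or untested is meant among the compounds shown, and "the series" means these compounds.

Measured compounds:
compound 1, `CSc1nc(NCCCCCO)c2ccccc2n1`: 31400 nM
compound 2, `CSc1nc(NCCCc2ccccc2)c2ccccc2n1`: 50600 nM
compound 3, `CCCCCSc1nc(O)c2ccccc2n1`: 30400 nM

In a functional assay on HTB-54 cells (Homo sapiens) for cytotoxicity, read by MTT assay, with a stated time of 72 h (on this read-out lower numbers stand for stronger inhibition of growth and higher numbers for weaker inhibition of growth), compound 1 gives the second highest of the three numbers; its nearest neighbour is compound 3, and all three values lie within the scatter of one another. Compound 4, `CSc1nc(Nc2ccccc2)c2ccccc2n1`, has not yet been measured. It differs from compound 1 in one place: phenyl in place of 5-hydroxypentyl on a nitrogen on an aromatic ring.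

Among the compounds with values here, the only measured step that touches the same part of the molecule is a 1.6-fold higher number from compound 1 to compound 2 (0.21 log units; within the scatter), where a phenyl replaced the hydroxy-bearing end of a chain rather than the whole chain. Nothing measured tests placing phenyl directly on the nitrogen, so the expected step of a 1.3-fold higher number from compound 1 to compound 4 (0.11 log units; within the scatter) is no larger than the scatter. The estimate for compound 4 is 40000 nM, with a range from 15000 nM to 110000 nM.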

Compound 4, concentration for 50% growth inhibition: 55800 nM
Beside the measured number, compound 4's estimate is 1.4-fold (0.14 log units) below it, within the range that was stated.
By their numbers in this assay, from the lowest: compounds 3, 1, 2 and 4 (each within the scatter of the next).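

In this assay the swap gives a 1.8-fold higher number from compound 1 to compound 4 (0.25 log units; within the scatter) even though a whole flexible chain with its hydrogen-bond donor and acceptor gives way to an aromatic ring with neither. Within the data shown here, compound 2 kept a chain on the nitrogen, so only this step shows that even a change of this kind at this position does not move the number beyond the scatter. No evidence here bears on why the values stay so close. From the compounds shown here alone, whether an amine, a carboxylic acid or a longer chain on this nitrogen would give a step beyond the scatter stays open.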